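A few compounds are considered here, and "the series" means these few. Any claim that something is new, unique, unknown or untested is made for them only; others in the source may bear on it.

- Compound 1 `O=C(NCc1ccc(S(=O)(=O)c2cccc(C(F)(F)F)c2)cc1)N1Cc2ccncc2C1`: 2.7 nM
- Compound 2 `O=C(NCc1ccc(S(=O)(=O)c2cncc(C(F)(F)F)c2)cc1)N1Cc2ccncc2C1`: 10 nM
- Compound 3 `O=C(NCc1ccc(S(=O)(=O)C2CCOCC2)cc1)N1Cc2ccncc2C1`: 35 nM

In a functional assay on A2780 cells (Homo sapiens) for cytotoxicity, read by sulforhodamine B assay, with a stated time of 72 h (on this read-out lower numbers stand for stronger inhibition and higher numbers for weaker inhibition), compound 3 gives 35 nM, the highest number and so the weakest inhibition of the three. Compound 4 `CCC(=O)N1CCC(S(=O)(=O)c2ccc(CNC(=O)N3Cc4ccncc4C3)cc2)CC1` changes one group: 1-propanoylpiperidin-4-yl in place of oxan-4-yl on a sulfonyl sulfur. In words, 1-propanoylpiperidin-4-yl stands in place of oxan-4-yl on a sulfonyl sulfur. Within the data shown here, no measured step tests this exact swap. The nearest evidence comes from changes at the same place, a 13-fold higher number from compound 1 to compound 3 (1.11 log units; beyond the scatter) and a 3.5-fold higher number from compound 2 to compound 3 (0.54 log units; beyond the scatter), which were large and modest and both involved losing an aromatic group. Compound 4 keeps a six-membered non-aromatic ring, so only a small move toward a lower number is expected, not clearly beyond the scatter. The estimated step is a 1.8-fold lower number from compound 3 to compound 4 (0.24 log units; within the scatter). For compound 4 the expected value is 20 nM, with an estimated range of 6 nM to 70 nM.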

Compound 4, half-maximal inhibitory concentration: 54 nM
Compound 4: the middle estimate sits 2.7-fold (0.43 log units) below what was measured, and the stated range covers the measured number.
By their numbers in this assay, from the lowest: compound 1; then compound 2; then compounds 3 and 4 (each within the scatter of the next).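

Replacing oxan-4-yl with 1-propanoylpiperidin-4-yl gives a 1.5-fold higher number from compound 3 to compound 4 (0.19 log units; within the scatter) in this assay and so leaves the number at this sulfonyl sulfur unresolved from that of compound 3, even with a propanoyl group added to the ring. The gap to the aromatic groups remains, with a 5.4-fold higher number from compound 2 to compound 4 (0.73 log units; beyond the scatter) and a 20-fold higher number from compound 1 to compound 4 (1.30 log units; beyond the scatter), so both non-aromatic compounds here stand apart from both aromatic ones. Nothing shown explains this gap. Still open, as far as these compounds go, is what a free amine at the piperidine nitrogen, or a longer chain in place of propanoyl, would give.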